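A few compounds are considered here, and "the series" means these few. Any claim that something is new, unique, unknown or untested is made for them only; others in the source may bear on it.

Measured compounds in an ADME assay on HEp-2 cells (Homo sapiens) for cytotoxicity; a higher number here means that more compound is tolerated, a lower number that less compound is tolerated:
compound 1 `Cc1ccc(NC(=O)CNS(=O)(=O)c2cccc3cccnc23)c(C)c1`, a limit: > 50000 nM
compound 2 `Cc1ccc(NC(=O)C(C)NS(=O)(=O)c2cccc3cccnc23)c(C)c1`, a limit: > 50000 nM
compound 3 `Cc1ccc(C(C)C)cc1NC(=O)[C@@H]1CCCN1S(=O)(=O)c1cccc2cccnc12`: 9700 nM

The value of compound 1 in this assay is a limit of the assay, not a number. The value of compound 2 in this assay is likewise a limit. The step that the two limits leave unreadable from compound 1 to compound 2, which is methyl in place of hydrogen on a saturated chain carbon bound to a carbonyl carbon and a sulfonamide nitrogen, therefore has no readable size, because of the limit of > 50000 nM in this assay, at which 2 of the 3 values shown sit. Among the compounds with values here, compound 3 gives the only number of the three; the difference between its core and the core of compound 1 is not broken down here.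

Compound 4 `Cc1ccc(C(C)(C)C)cc1NC(=O)[C@@H]1CCCN1S(=O)(=O)c1cccc2cccnc12` is not yet measured in this assay. It arises from compound 3 by methyl in place of hydrogen on a saturated chain carbon bound to an aromatic carbon and two saturated chain carbons. This is the same kind of change as from compound 1 to compound 2, but not the same: there the methyl entered on a saturated chain carbon bound to a carbonyl carbon and a sulfonamide nitrogen, here on a saturated chain carbon bound to an aromatic carbon and two saturated chain carbons. The measured step offers no readable size to lean on. The expected step from compound 3 to compound 4 is a 1.2-fold lower number from compound 3 to compound 4 (0.08 log units; within the scatter), kept close to compound 3 at 9700 nM. The estimate for compound 4 is 8000 nM, expected to lie between 3000 nM and 25000 nM.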

Compound 4, half-maximal cytotoxic concentration: 6500 nM
The estimate for compound 4 lay 1.2-fold (0.09 log units) above the measured number; the measured number falls inside the stated range.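

In this assay, the change from isopropyl to tert-butyl gives a 1.5-fold lower number from compound 3 to compound 4 (0.17 log units; within the scatter), so on this core the added methyl produces no shift beyond the scatter. The methyl step on the core of compound 1 sits at a different place and cannot be read, because the values of compound 1 and compound 2 are both limits of the assay: the limit of > 50000 nM in this assay, at which 2 of the 4 values shown sit. The series therefore holds one readable methyl step on one core, which shows nothing yet about how this change carries from one core to another.

Still open, as far as these compounds go, is how this assay responds when a carboxylic acid, an amine or a longer chain stands in place of the isopropyl or tert-butyl group. Also open, from the compounds shown here alone, is whether tert-butyl on the core of compound 1 would bring a readable number.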